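Urea series: solubility of compound 3

This account rests on a few compounds, and the source may have more. Where it says the series, first, only, none or still open, it means among the compounds named here.

Measured so far:
- Compound 1, `Cc1cc(NC(=O)Nc2cccc(F)c2)c2ccccc2n1`: 100 nM
- Compound 2, `COC(=O)c1cccc(NC(=O)Nc2cc(C)nc3ccccc23)c1`: 600 nM

For the measured compounds named here, in a physicochemical assay for solubility, at pH 7.4 (a lower number here means a less soluble compound, a higher number a more soluble compound), compound 1 gives the lowest of the two numbers; the nearest is compound 2, and the step of a 6.0-fold higher number from compound 1 to compound 2 (0.78 log units; beyond the scatter) is the only measured step in the set.

Compound 3, `Cc1cc(NC(=O)Nc2ccc(Cl)cc2)c2ccccc2n1`, has not been measured. It differs from compound 1 as follows: 4-chlorophenyl in place of 3-fluorophenyl on an amide-type nitrogen. Going by the values given here, the one measured step exchanges fluoro for methoxycarbonyl on an aromatic carbon and does not bear on a swap of one halogen-bearing phenyl for another; no measured pair shows such a swap. With nothing in the data to point either way, the step of a 1.1-fold lower number from compound 1 to compound 3 (0.05 log units; within the scatter) is expected to stay within the scatter, with no direction assumed.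

Compound 3 is therefore estimated at 90 nM in this assay, with a range of 35 nM to 250 nM.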

Compound 3, solubility: 1400 nM
Compound 3: middle estimate off by 16-fold (1.19 log units), on the low side, and the stated range ends below it.
By their numbers in this assay, from the lowest: compound 1; then compound 2; then compound 3.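

Notes on the urea series, this assay: the aryl group on the amide-type nitrogen is a sensitive place, since 4-chlorophenyl in place of 3-fluorophenyl gives a large step (a 14-fold higher number from compound 1 to compound 3 (1.15 log units; beyond the scatter)). The earlier step changed fluoro to methoxycarbonyl, whereas here the two groups match in heavy-atom count, ring, hydrogen-bond donor and acceptor counts and net charge, so a swap that leaves all these counts unchanged can still move the number well beyond the scatter. Nothing available on the compounds accounts for the size of this step.

On these data alone, the halogen and its place on the phenyl ring change together in this single pair, so which of the two carries the step stays open. How an amine or a carboxylic acid on that phenyl ring would read also remains outside what the compounds shown can tell.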